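Removing a Fluoro Group From Compound 2

This account rests on a few compounds, and the source may have more. Where it says the series, first, only, none or still open, it means among the compounds named here.

Compound 1 `Nc1scc(CN2CCN(c3c(F)cccc3F)CC2)c1C(=O)c1ccc(Cl)cc1`: 4%
Compound 2 `Nc1scc(CN2CCN(c3ccc(F)c(Cl)c3)CC2)c1C(=O)c1ccc(Cl)cc1`: 0%

In an assay on CHO cells for displacement of a labelled ligand from adenosine receptor A3 (Homo sapiens), read by scintillation counting, with a stated time of 120 min, tested at 10 uM (on this read-out higher numbers stand for more inhibition at the one concentration tested (going by the name of the read-out) and lower numbers for less inhibition), compound 1 gives 4% and compound 2 gives 0%. Compound 2 stands alongside compound 1, since the step of a number 4 percentage points lower from compound 1 to compound 2 (within the scatter) lies within the scatter. Compound 3 `Nc1scc(CN2CCN(c3cccc(Cl)c3)CC2)c1C(=O)c1ccc(Cl)cc1` differs from compound 2 by hydrogen in place of fluoro on an aromatic carbon. Among the measured compounds shown here, the one measured step that bears on this, a number 4 percentage points lower from compound 1 to compound 2 (within the scatter), also altered the same aryl group and stayed within the scatter, so no step beyond the scatter is expected here either. Compound 3 is therefore estimated at 2%, within a range of -8% to 12%. The expected step is a number 2 percentage points higher from compound 2 to compound 3 (within the scatter).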

Compound 3, a percentage reported as inhibition, at one concentration (the size of the read-out at that concentration, not a potency): 1%
Estimate against measurement, compound 3: 1 percentage points above; measured number inside the range.
By their numbers in this assay, from the lowest: compounds 2, 3 and 1 (each within the scatter of the next).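

In this assay, hydrogen in place of fluoro on the aromatic carbon ortho to the chloro group gives a number 1 percentage points higher from compound 2 to compound 3 (within the scatter), so removing this fluoro group leaves the read-out within the scatter. Against the 2,6-difluorophenyl group, the 3-chlorophenyl group gives a number 3 percentage points lower from compound 1 to compound 3 (within the scatter), which places all three aryl groups within the scatter of one another. No evidence is available that bears on this result.

Still open, as far as these compounds go, is how a methoxy group or an amine on this aromatic carbon would read. Also open, from the compounds shown here alone, is whether replacing the chloro group with a nitrile would change the number.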